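Selenocyanate to alkenyl amide swap in the trimethoxyphenyl series

The compounds below may be only part of what the source reports. "The series", "measured", "known", "first", "only" and "open" are said of these compounds alone.

Measured so far:
- compound 1, `COc1ccc(CN(C(=O)C[Se]C#N)c2cc(OC)c(OC)c(OC)c2)cc1O`: 280 nM
- compound 2, `C/C=C/C(=O)N(Cc1ccc(OC)cc1)c1cc(OC)c(OC)c(OC)c1`: 420 nM

In a functional assay on KYSE-450 cells (Homo sapiens) for inhibition, read by MTT assay, with a stated time of 48 h (a higher number here means a weaker inhibitor, a lower number a stronger inhibitor), compound 1 gives 280 nM and compound 2 gives 420 nM; the two values lie within the scatter of each other, so neither can be set apart. Compound 3, `CC/C=C/C(=O)N(Cc1ccc(OC)c(O)c1)c1cc(OC)c(OC)c(OC)c1`, has not yet been tested in this assay. It differs from compound 1 by a group of 4 heavy atoms (4 carbon; no ring) in place of a group of 4 heavy atoms (2 carbon, 1 nitrogen, 1 selenium; no ring), on a carbonyl carbon. Among the measured compounds shown here, no measured pair isolates this change, and the two values known so far suggest the series tolerates different substituents on the carbonyl carbon without a clear shift. The step of a 1.3-fold higher number from compound 1 to compound 3 (0.10 log units; within the scatter) is therefore expected to stay within the scatter. For compound 3 the expected value in this assay is 350 nM, with a range of 150 nM to 800 nM.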

Compound 3, half-maximal inhibitory concentration: 72 nM
Compound 3: the middle estimate sits 4.9-fold (0.69 log units) above what was measured; measured number outside the range, below it.
By their numbers in this assay, from the lowest: compound 3; then compounds 1 and 2 (each within the scatter of the next).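

In this assay, but-1-en-1-yl in place of the selenium-containing group on the carbonyl carbon gives a 3.9-fold lower number from compound 1 to compound 3 (0.59 log units; beyond the scatter), so this position does respond to its substituent, which the earlier pair could not show. Selenium is not required here, since the all-carbon group gives the lower number. No measurement shown accounts for this difference.

On these data alone, it remains open whether the double bond or the chain itself matters at this position. A saturated butyl chain, a longer alkenyl chain or an amine on the carbonyl carbon would help separate these.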